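Notes on compound 4 against compound 2

This account rests on a few compounds, and the source may have more. Where it says the series, first, only, none or still open, it means among the compounds named here.

Compound 2 `COc1cc(-c2ccnc3cc(-c4ccc5cc[nH]c5c4)nn23)cc(OC)c1OC` has the lowest of the two numbers given in a functional assay on MCF7 cells (Homo sapiens) for inhibition, read by CCK-8 assay, with a stated time of 48 h; on this read-out higher numbers stand for weaker inhibition and lower numbers for stronger inhibition: compound 2 gives 23 nM. Among the compounds with values here, compound 1 `COc1cc(-c2ccnc3cc(-c4ccc(Cl)cc4)nn23)cc(OC)c1OC` gives 2320 nM, and the only single-point step so far, a 100-fold lower number from compound 1 to compound 2 (2.00 log units; beyond the scatter), is 1H-indol-6-yl replacing 4-chlorophenyl. Compound 3 `COc1ccc(-c2cc3nccc(-c4cc(OC)c(OC)c(OC)c4)n3n2)cc1[N+](=O)[O-]` sits at a limit, > 10000 nM, not at a number. Compound 4 `COc1cc(-c2ccnc3cc(-c4ccc5ccn(C)c5c4)nn23)cc(OC)c1OC` differs from compound 2 by methyl in place of hydrogen on an aromatic nitrogen, so 1H-indol-6-yl becomes 1-methyl-1H-indol-6-yl. Within the data shown here, no measured step touches that nitrogen; the one large step concerns the whole aryl group and gives no guide to its methylation. The expected step of a 1.7-fold higher number from compound 2 to compound 4 (0.24 log units; within the scatter) is therefore modest, within the scatter or a slight rise. Compound 4 is estimated at 40 nM, range 10 nM to 160 nM.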

Compound 4, half-maximal inhibitory concentration: 74 nM
For compound 4 the middle estimate is 1.9-fold (0.27 log units) below the measured one; the measured number falls inside the stated range.
By their numbers in this assay, from the lowest: compound 2; then compound 4; then compound 1. At a limit, above all of these: compound 3.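

Methyl in place of hydrogen on the aromatic nitrogen is tolerated only at a cost: a 3.2-fold higher number from compound 2 to compound 4 (0.51 log units; beyond the scatter) is a modest step, though beyond the scatter. Most of the gain from the indole survives that change, with a 31-fold lower number from compound 1 to compound 4 (1.50 log units; beyond the scatter) still a large step, so the free nitrogen hydrogen is not required for a low number in this pair. No measurement shown here gives a cause for the rise.

This single pair cannot separate loss of the hydrogen from addition of the methyl. Going by these compounds, how an ethyl group, a longer chain or a chain ending in an amine on that nitrogen would read remains open.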